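Extending the acyl chain on a phenolic Schiff base

A few compounds are considered here, and "the series" means these few. Any claim that something is new, unique, unknown or untested is made for them only; others in the source may bear on it.

The shared core carries a phenol-derived ester and a pyridylmethyl imine. Compound 1 `CCCCCCC(=O)Oc1ccc(/C=N/Cc2cccnc2)cc1` is the heptanoate ester of this core, and compound 2 `Oc1ccc(/C=N/Cc2cccnc2)cc1` is the free phenol with the same imine. In a functional assay on MCF7 cells (Homo sapiens) for cytotoxicity (on this read-out lower numbers stand for stronger inhibition and higher numbers for weaker inhibition), compound 2 gives 12000 nM, while compound 1 is reported only as "not active" (no number reported), with no number attached. Compound 1 therefore stands without a single value to place it on the scale; all that can be said is that the phenol, compound 2, does have a measurable number and the heptanoate does not.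

Compound 3 `CCCCCCCCCCCCCC(=O)Oc1ccc(/C=N/Cc2cccnc2)cc1` differs from compound 1 by heptyl in place of hydrogen on a saturated chain carbon, six bonds along the chain from a carbonyl carbon. For the measured compounds named here, no step between measured compounds is available to calibrate this change. Since compound 1 already gave no number, a step of any size in this assay from compound 1 to compound 3 cannot be resolved; the expectation is that compound 3 remains in the same weak region, with a substantial chance that again only a limit is reported. The estimate for compound 3 in this assay is 50000 nM, within a range of 12000 nM to 200000 nM.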

Compound 3, half-maximal inhibitory concentration: "not active" (no number reported)
The entry for compound 3 holds no number; the estimate stays without a comparison.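

In this assay, for the compounds shown here, compound 3 gives "not active" (no number reported) and compound 1 gives "not active" (no number reported), so no step between these two compounds can be read. The compounds shown leave open whether the longer chain of compound 3 changes cytotoxicity at all, since neither ester has a number on this scale. No measurement shown here offers an explanation for this result.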